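This account rests on a few compounds, and the source may have more. Where it says the series, first, only, none or still open, it means among the compounds named here.

Compound 1 `COc1cccc(/C=C/C(=O)Nc2cc(OC)c(OC)c(OC)c2)c1` gives 17300 nM in a functional assay on ME-180 cells (Homo sapiens) for cytotoxicity, read by MTT assay, with a stated time of 72 h; on this read-out lower numbers stand for stronger inhibition and higher numbers for weaker inhibition. Compound 2 `C#CCOc1cccc(/C=C/C(=O)Nc2cc(C(=O)c3cc(OC)c(OC)c(OC)c3)ccc2OC)c1` gives 15300 nM. Compound 3 `COc1ccc(C(=O)c2cc(OC)c(OC)c(OC)c2)cc1NC(=O)/C=C/c1cccc(OC(F)(F)F)c1` gives 9200 nM.

Among these three values compound 2 stands second highest; its nearest neighbour is compound 1 and its furthest is compound 3, and both gaps lie within the scatter of repeated measurements, so no order among them can be claimed. Compound 4 `COc1ccc(C(=O)c2cc(OC)c(OC)c(OC)c2)cc1NC(=O)/C=C/c1ccc(F)c(F)c1` has not yet been measured. It differs from compound 2 by 3,4-difluorophenyl in place of 3-(propargyloxy)phenyl on a double-bonded chain carbon bound to a double-bonded chain carbon. Among the measured compounds shown here, the only measured step that touches the same part of the molecule is a 1.7-fold lower number from compound 2 to compound 3 (0.22 log units; within the scatter), which left the number essentially unchanged. Compound 4 is therefore expected to give a number close to that of compound 2, and the step of a 1.4-fold lower number from compound 2 to compound 4 (0.14 log units; within the scatter) is estimated to stay within the scatter. Compound 4 is estimated at 11000 nM, between 3500 nM and 35000 nM.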

Compound 4, half-maximal inhibitory concentration: 8900 nM
Compound 4: middle estimate off by 1.2-fold (0.09 log units), on the high side, within the range that was stated.
By their numbers in this assay, from the lowest: compounds 4, 3, 2 and 1 (each within the scatter of the next).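

In this assay, the 3-(propargyloxy)phenyl and 3-(trifluoromethoxy)phenyl groups can each give way to 3,4-difluorophenyl, which carries no oxygen and no triple bond, with only small steps (a 1.7-fold lower number from compound 2 to compound 4 (0.24 log units; within the scatter); a 1.0-fold lower number from compound 3 to compound 4 (0.01 log units; within the scatter)). The ring at this place can therefore change its substituents in more than one way while the numbers stay within the scatter. No measurement here explains this result. Going by these compounds, whether an amine or a carboxylic acid on this ring would shift the number remains open. So does the effect of a longer chain in place of the ethenyl link.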